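The source may report more compounds than this note shows. Statements on the series, on what has been measured and on what is new or still open speak of the compounds shown alone.

In an ADME assay on microsomes from liver (Mus musculus) for metabolic stability, read by LC-MS, using NADPH, with stated times of 10 min and 30 min, tested at 1 uM (on this read-out higher numbers stand for fast clearance and lower numbers for slow clearance), compound 1 `COC(=O)C1=C(CN2CCOCC2=O)NC(c2nccs2)=NC1(C)c1ccc(F)cc1` gives 80 mL/min/kg and compound 2 `COC(=O)C1=C(CN(C)C2(C(=O)O)CC2)NC(c2nccs2)=NC1(C)c1ccc(F)cc1` gives 42 mL/min/kg, so compound 2 stands within the scatter of the only other number shown. Compound 3 `COC(=O)C1=C(COCC(F)(F)F)NC(c2nccs2)=NC1(C)c1ccc(F)cc1` keeps the shared core but carries 2,2,2-trifluoroethoxy in place of the cyclopropane-bearing group of compound 2, on a saturated chain carbon bound to a double-bonded ring carbon: a group of 6 heavy atoms (2 carbon, 1 oxygen, 3 fluorine; no ring) in place of a group of 8 heavy atoms (5 carbon, 1 nitrogen, 2 oxygen; one three-membered non-aromatic ring of carbon only), on a saturated chain carbon bound to a double-bonded ring carbon. Going by the values given here, only one measured step bears on this place, a 1.9-fold lower number from compound 1 to compound 2 (0.28 log units; within the scatter). That step exchanged two groups that both hold nitrogen and a ring, whereas the entering group here holds neither, so the guidance is limited. With that single step as the guide, no change beyond the scatter is expected in this assay, and the estimated step is a 1.5-fold higher number from compound 2 to compound 3 (0.19 log units; within the scatter). Compound 3 is expected at 65 mL/min/kg, with an estimated range from 30 mL/min/kg to 125 mL/min/kg.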

Compound 3, clearance: 81 mL/min/kg
The estimate for compound 3 lay 1.2-fold (0.10 log units) below the measured number, and the stated range covers the measured number.
By their numbers in this assay, from the lowest: compounds 2, 1 and 3 (each within the scatter of the next).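

With 2,2,2-trifluoroethoxy on the saturated chain carbon bound to a double-bonded ring carbon, compound 3 stays within the scatter of both earlier compounds in this assay: the result is a 1.9-fold higher number from compound 2 to compound 3 (0.29 log units; within the scatter) and a 1.0-fold higher number from compound 1 to compound 3 (0.01 log units; within the scatter). The entering group holds no nitrogen, no ring and no hydrogen-bond donor, so all three groups shown at this place, which differ in these counts, give numbers that lie within the scatter of one another. No measurement shown here explains these numbers.

Going by these compounds, it remains open whether any group at this place can give a step beyond the scatter in this assay. A primary amine or a longer carbon chain on the same saturated chain carbon would test this.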